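Acrylamide chain variation on the indole-pyrimidine series

The source may hold more compounds than are shown below. What is called first, only, known or untested is meant among the compounds shown, and "the series" means these compounds.

Of the compounds shown here, three of a shared core have been measured. In a functional assay on NCI-H1975 cells (Homo sapiens) for antiproliferative activity, read by MTT assay, with a stated time of 72 h (a lower number here means a stronger inhibitor, a higher number a weaker inhibitor), compound 1 `C=C(F)C(=O)Nc1cc(Nc2nccc(-c3cn(C)c4ccccc34)n2)c(OC)cc1N(C)CCN(C)C` gives 4230 nM, compound 2 `C=C(Cl)C(=O)Nc1cc(Nc2nccc(-c3cn(C)c4ccccc34)n2)c(OC)cc1N(C)CCN(C)C` gives 1290 nM and compound 3 `C=C(Cl)C(=O)Nc1cc(Nc2ncc(C#N)c(-c3cn(C)c4ccccc34)n2)c(OC)cc1N(C)CCN(C)C` gives 1620 nM. Compound 3 thus stands second highest of the three numbers, nearest to compound 2 and furthest from compound 1. The two measured steps are a 3.3-fold lower number from compound 1 to compound 2 (0.52 log units; beyond the scatter) and a 1.3-fold higher number from compound 2 to compound 3 (0.10 log units; within the scatter).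

Compound 4 `CCC/C=C\C(=O)Nc1cc(Nc2ncc(C#N)c(-c3cn(C)c4ccccc34)n2)c(OC)cc1N(C)CCN(C)C` differs from compound 3 by pent-1-en-1-yl in place of 1-chloroethenyl on a carbonyl carbon. For the measured compounds named here, of the measured steps only a 3.3-fold lower number from compound 1 to compound 2 (0.52 log units; beyond the scatter) touches the same carbonyl-bound chain, and that step exchanged one halogen for another; no step removes the halogen or lengthens the chain, so the present change has no close precedent here. With nothing to anchor it, a modest shift towards a higher number, a 2.0-fold higher number from compound 3 to compound 4 (0.30 log units; within the scatter), is expected, held with a wide range. Compound 4 is therefore estimated at 3200 nM, between 800 nM and 13000 nM.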

Compound 4, half-maximal inhibitory concentration: 823 nM
Compound 4: the middle estimate sits 3.9-fold (0.59 log units) above what was measured; measured number inside the range.
By their numbers in this assay, from the lowest: compounds 4, 2 and 3 (each within the scatter of the next); then compound 1.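

In this assay the exchange of 1-chloroethenyl for pent-1-en-1-yl on a carbonyl carbon gives a 2.0-fold lower number from compound 3 to compound 4 (0.29 log units; within the scatter) and so leaves compound 3 and compound 4 not separated. For the compounds shown here, the only earlier step on this chain, a 3.3-fold lower number from compound 1 to compound 2 (0.52 log units; beyond the scatter), lay beyond the scatter, whereas here removing the halogen and going from 3 to 5 heavy atoms in the group does not move the number beyond it. No measurement at hand bears on why this exchange is tolerated.

Going by these compounds, whether a longer chain than pent-1-en-1-yl, or a chain carrying a dimethylamino group, stays in the same range remains open. Also open, on these data alone, is whether pent-1-en-1-yl behaves alike on the core of compound 2, which lacks the nitrile.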